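Chloro in Place of Methyl: Expected Tolerance

This account rests on a few compounds, and the source may have more. Where it says the series, first, only, none or still open, it means among the compounds named here.

Compound 1, `S=C(Nc1ccc(Cl)cc1)OCCc1ccccn1`: 52000 nM in an ADME assay on MT4 cells (Homo sapiens) for cytotoxicity, read by MTT assay; a higher number here means that more compound is tolerated, a lower number that less compound is tolerated.
Compound 2, `Cc1ccc(NC(=S)OCCc2ccncc2)cc1`: > 100000 nM in this assay, a limit of the assay rather than a number.

Compound 2 therefore stands at the limit of > 100000 nM in this assay, at which 1 of the 2 values shown sits. Compound 3, `S=C(Nc1ccc(Cl)cc1)OCCc1ccncc1`, is reached by chloro in place of methyl on an aromatic carbon. Among the measured compounds shown here, no measured pair shows this change, so its size is open; since compound 1, which also carries chloro, gives 52000 nM, a modest downward move toward that region is expected, but one that may stay within scatter. The step is expected as an at least 1.4-fold lower number from compound 2 to compound 3 (0.15 log units; that floor lies within the scatter). Compound 3 is expected to give 70000 nM, within 30000 nM to 150000 nM.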

Compound 3, half-maximal cytotoxic concentration: 70000 nM
Beside the measured number, compound 3's estimate shows no gap at the digits printed; measured number inside the range.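

In this assay, chloro in place of methyl on an aromatic carbon gives an at least 1.4-fold lower number from compound 2 to compound 3 (0.15 log units; that floor lies within the scatter). That step is only a floor, because compound 2 stands at a limit of the assay: the limit of > 100000 nM in this assay, at which 1 of the 3 values shown sits.

With chloro on the ring, pyridin-4-yl in place of pyridin-2-yl gives a 1.3-fold higher number from compound 1 to compound 3 (0.13 log units; within the scatter), so this change does not separate the two compounds. Going by these compounds, the full size of the chloro-for-methyl step remains open, since compound 2 has no exact number. Also open, on these data alone, is how a methoxy group at that ring position, or a longer chain in the linker, would read.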